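The source may report more compounds than this note shows. Statements on the series, on what has been measured and on what is new or still open speak of the compounds shown alone.

Series notes, step from compound 1 to compound 3.

Two ureas on the shared core have been measured. Compound 1 `COc1ccccc1NC(=O)Nc1cccc(CNc2nccnc2Cl)c1` gives 12200 nM in a functional assay on MGC-803 cells (Homo sapiens) for antiproliferative activity, read by MTT assay, with a stated time of 48 h; on this read-out higher numbers stand for weaker inhibition and lower numbers for stronger inhibition; compound 2 `Cc1cccc(NC(=O)Nc2cccc(CNc3nccnc3Cl)c2)c1` gives 14600 nM in the same assay. Compound 1 holds the lower of the two numbers, but the step of a 1.2-fold higher number from compound 1 to compound 2 (0.08 log units; within the scatter) is within the scatter, so neither compound can be placed ahead of the other.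

Compound 3 `O=C(Nc1cccc(CNc2nccnc2Cl)c1)NC1CCCCC1` is not yet measured. Against compound 1 the change is cyclohexyl in place of 2-methoxyphenyl on an amide-type nitrogen. Within the data shown here, the only measured step, from compound 1 to compound 2, exchanges one aryl group for another on the same amide-type nitrogen and does not move the number beyond the scatter; no step exchanges an aryl group for a saturated ring, so there is no direct precedent for this change. Among the measured compounds shown here, with the one aryl-to-aryl exchange showing no movement, the expectation for compound 3 is a number close to that of compound 1, widened toward weaker inhibition to cover the untested kind of change, which is expected to read as a 1.5-fold higher number from compound 1 to compound 3 (0.17 log units; within the scatter). For compound 3 the estimate is 18000 nM, with a range from 6000 nM to 55000 nM.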

Compound 3, half-maximal inhibitory concentration: > 40000 nM
Compound 3: only a limit was reported; the forecaster's own chance of this, stated with the estimate: 15%; middle value at least 2.2-fold (0.34 log units) from the limit.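

Compound 3 gives only a limit of the assay, not a number: the limit of > 40000 nM in this assay, at which 1 of the 3 values shown sits.

Among these compounds, the aryl-for-aryl exchange on this amide-type nitrogen stays within the scatter (a 1.2-fold higher number from compound 1 to compound 2 (0.08 log units; within the scatter)), whereas cyclohexyl in place of an aryl group gives the first steps to lie beyond it, both toward weaker inhibition: an at least 3.2-fold higher number from compound 1 to compound 3 (0.51 log units; beyond the scatter) and an at least 2.7-fold higher number from compound 2 to compound 3 (0.43 log units; beyond the scatter). The position is therefore not indifferent to the group it carries: the two aryl ureas cannot be told apart, yet each reads stronger than the cyclohexyl urea.

The limit fixes only a minimum for the size of these steps, and a single saturated ring cannot show whether the aromatic ring itself is what matters or whether cyclohexyl is a special case. Also open, from the compounds shown here alone, is how the shared core would read with an open hexyl chain on this nitrogen, with a piperidine ring in place of cyclohexyl, or with a phenyl group carrying an amine or a carboxylic acid.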